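Methyl to Fluoro: Expected Cytotoxicity of Compound 4

This account rests on a few compounds, and the source may have more. Where it says the series, first, only, none or still open, it means among the compounds named here.

Compound 1, `Cc1ccc(/C=C2\CCC/C(=C\c3ccccc3[N+](=O)[O-])C2=O)cc1`, gives 7770 nM in a functional assay on L1210 cells (Mus musculus) for cytotoxicity, with a stated time of 48 h; on this read-out higher numbers stand for weaker inhibition and lower numbers for stronger inhibition.
Compound 2, `Cc1ccc(/C=C2\CCC/C(=C\c3cccc([N+](=O)[O-])c3)C2=O)cc1`, gives 41800 nM in this assay.
Compound 3, `Cc1ccc(/C=C2\CCC/C(=C\c3ccc([N+](=O)[O-])cc3)C2=O)cc1`, gives 8160 nM in this assay.

Three compounds share one core and differ only in where the nitro group sits on one of the two aromatic rings. Compound 3 has the second highest of the three numbers. Its value and that of compound 1 lie within the usual scatter of each other, so nothing can be said about which of the two is stronger. Compound 2 stands furthest away, with a higher number that lies beyond the scatter.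

Compound 4, `O=C1/C(=C/c2ccc(F)cc2)CCC/C1=C\c1ccc([N+](=O)[O-])cc1`, keeps the nitro group of compound 3 in place and changes the other aromatic ring: fluoro in place of methyl on an aromatic carbon. Going by the values given here, no measured pair in this set shows what such a swap does in this assay. A small group is replaced by another small group of the same size, with no change in donors, acceptors or charge, so the expected step from compound 3 to compound 4 is none beyond the scatter, in either direction: a 1.0-fold lower number from compound 3 to compound 4 (0.01 log units; within the scatter). Compound 4 is therefore estimated at 8000 nM, with a plausible range from 3000 nM to 22000 nM.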

Compound 4, half-maximal inhibitory concentration: 26800 nM
Beside the measured number, compound 4's estimate is 3.4-fold (0.53 log units) below it; measured number outside the range, above it.
By their numbers in this assay, from the lowest: compounds 1 and 3 (each within the scatter of the next); then compounds 4 and 2 (each within the scatter of the next).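

Up to this point only the nitro group had moved, so the ring carrying the methyl group had not been tested. In this assay, fluoro in place of methyl on that ring gives a 3.3-fold higher number from compound 3 to compound 4 (0.52 log units; beyond the scatter), a modest step but one beyond the usual scatter. The para place on this ring is therefore not indifferent to the group it carries: exchanging one small group for another, with no hydrogen-bond donor, acceptor or charge entering or leaving, still weakens inhibition, and nothing available here accounts for this.

The compounds shown carry only methyl and fluoro at this place, so it remains open whether a chlorine atom, a methoxy group or an amine there would give a number nearer to that of compound 3 or to that of compound 4. Going by these compounds, this is also a single pair, and it remains open whether the same swap gives a similar step when the nitro group sits where it does in compound 1 or in compound 2.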